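Allyl in place of vinyl on the aromatic ring

A few compounds are considered here, and "the series" means these few. Any claim that something is new, unique, unknown or untested is made for them only; others in the source may bear on it.

For the measured compounds named here, in a functional assay (brain) with Rattus norvegicus as the target (on this read-out lower numbers stand for stronger inhibition and higher numbers for weaker inhibition), compound 3 (`C=Cc1ccc([C@H]2CCN(C)C[C@H]2C(=O)OC)cc1`) gives 155 nM and stands highest of the three numbers so far. Lower lie compound 2 (`COC(=O)[C@H]1CN(C)CC[C@@H]1c1ccc2ccccc2c1`) at 46 nM and compound 1 (`COC(=O)[C@@H]1CN(C)CC[C@@H]1c1ccc2ccccc2c1`) at 8.2 nM on the same read-out.

Compound 4 (`C=CCc1ccc([C@H]2CCN(C)C[C@H]2C(=O)OC)cc1`) departs from compound 3 by allyl in place of vinyl on an aromatic carbon with allyl in place of vinyl on an aromatic carbon, para to a large group.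

Going by the values given here, the only measured step is a 5.6-fold higher number from compound 1 to compound 2 (0.75 log units; beyond the scatter) and it is modest. Among the compounds with values here, it comes with the fact that compounds 1 and 2 differ only in the configuration as drawn and so offers only a rough scale, as no measured step involves a change at this aromatic carbon. Taking compound 3 at 155 nM as the starting point, no step beyond the scatter is firmly expected in this assay, with a slight lean towards a higher number. The estimated change is a 1.4-fold higher number from compound 3 to compound 4 (0.15 log units; within the scatter) in all.

For compound 4 the estimated value is 220 nM with an expected range from 70 nM to 650 nM as a wide allowance.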

Compound 4, half-maximal inhibitory concentration: 334 nM
For compound 4 the middle estimate is 1.5-fold (0.18 log units) below the measured one; the measured number falls inside the stated range.
By their numbers in this assay, from the lowest: compound 1; then compound 2; then compound 3; then compound 4.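

In this assay, for the compounds shown here, the first measured change at this aromatic carbon, para to a large group, is vinyl to allyl, which gives a 2.2-fold higher number from compound 3 to compound 4 (0.33 log units; beyond the scatter). Going by these compounds alone, the earlier compounds offered only a difference in configuration, so this is the first sign that the read-out responds to the substituent here, and the direction is towards weaker inhibition. Hydrogen-bond donors, hydrogen-bond acceptors, net charge and the count of double bonds outside aromatic rings stay the same, leaving the heavy-atom count of 2 against 3 as the only difference counted, and nothing at hand explains the step.

A single pair cannot show whether a longer chain, such as butenyl, continues this direction. Also open, from the compounds shown here alone, are how a saturated propyl chain, an amine or a carboxylic acid on this carbon would read.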